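This account rests on a few compounds, and the source may have more. Where it says the series, first, only, none or still open, it means among the compounds named here.

In an ADME assay on MT4 cells (Homo sapiens) for cytotoxicity, with a stated time of 5 days (a lower number here means that less compound is tolerated, a higher number that more compound is tolerated), compound 1 (`CC(C)N(C(=O)C1CCC(F)(F)CC1)c1cc(C#CC(C)(C)C)sc1C(=O)O`) gives > 20000 nM as a limit of the assay and not a number. Compound 2 (`CC(C)N(C(=O)C1CCCCCC1)c1cc(C#CC(C)(C)C)sc1C(=O)O`) likewise gives > 20000 nM as a limit, so it has no exact standing on the numbers shown. Compound 3 (`CC(C)N(C(=O)[C@@H]1CC[C@@H]2C[C@@H]2CC1)c1cc(C#CC(C)(C)C)sc1C(=O)O`) differs from compound 2 as follows: a group of 8 heavy atoms (8 carbon; one three-membered non-aromatic ring of carbon only, one seven-membered non-aromatic ring of carbon only) in place of a group of 7 heavy atoms (7 carbon; one seven-membered non-aromatic ring of carbon only), on a carbonyl carbon. For the measured compounds named here, the one measured step that bears on this change, replacing the group on the same carbonyl carbon, is a step that the two limits leave unreadable from compound 1 to compound 2 and it has no readable size. The evidence is the limit of > 20000 nM in this assay, at which 2 of the 2 values shown sit, and it points in no direction. No step beyond the usual scatter is therefore expected in this assay. The expected step is a number no higher from compound 2 to compound 3 (the limit leaves the size open) and it is only an estimate. For compound 3 the estimated value is 20000 nM with a range from 10000 nM to 40000 nM expected.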

Compound 3, half-maximal cytotoxic concentration: > 20000 nM
Compound 3: no number, only a limit; the forecaster's own chance of this, stated with the estimate: 80%; the middle value lies on the limit itself.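

In this assay compound 3 gives > 20000 nM, a limit of the assay and not a number. For the compounds shown here, no step from compound 1 or compound 2 to compound 3 can therefore be read. Whether the groups on the carbonyl carbon differ at all in this read-out stays open, as all that is seen is this: the limit of > 20000 nM in this assay, at which 3 of the 3 values shown sit.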